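The source may hold more compounds than are shown below. What is called first, only, known or untested is meant among the compounds shown, and "the series" means these compounds.

Measured compounds:
compound 1 `O=Cc1cn(-c2ccccc2)nc1-c1cccc([N+](=O)[O-])c1` — 75%
compound 2 `COc1cc(/C=C/C(=O)C(=Cc2cn(-c3ccccc3)nc2-c2ccc([N+](=O)[O-])cc2)C(=O)/C=C/c2ccc(O)c(OC)c2)ccc1O` — 90%

In a functional assay on MCF7 cells (Homo sapiens) for antiproliferative activity, read by MTT assay, with a stated time of 24 h, tested at 1 ug/mL (a lower number here means a stronger effect, a higher number a weaker effect of the compound at the concentration tested), compound 1 gives 75%. In this assay compound 2 gives 90%, the highest of the two numbers, above compound 1 by a gap that lies beyond the usual scatter. Among the compounds with values here, these two compounds differ in more than one place, so no single structural step between them is available.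

Compound 3 `COc1cc(/C=C/C(=O)C(=Cc2cn(-c3ccccc3)nc2-c2ccccc2O)C(=O)/C=C/c2ccc(O)c(OC)c2)ccc1O` has not yet been measured. Within the data shown here, its single change from compound 2 is 2-hydroxyphenyl in place of 4-nitrophenyl on an aromatic carbon. Among the measured compounds shown here, no measured pair shows the effect of this exact change, so the expectation must rest on compound 2 alone. The expected step is a number 5 percentage points lower from compound 2 to compound 3 (within the scatter), a small shift downward that may well stay within the scatter. Compound 3 is therefore estimated at 85%, with a range from 65% to 100%.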

Compound 3, a percentage reported as activity, at one concentration (the size of the read-out at that concentration, not a potency): 88%
Compound 3: the middle estimate sits 3 percentage points below what was measured; the range from low to high includes it.
By their numbers in this assay, from the lowest: compound 1; then compounds 3 and 2 (each within the scatter of the next).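

In this assay, placing 2-hydroxyphenyl where compound 2 carries 4-nitrophenyl gives a number 2 percentage points lower from compound 2 to compound 3 (within the scatter), so the read-out does not separate these two groups at this position. Within the data shown here, this is the first comparison here in which only one place differs, and it shows that two differently substituted phenyl rings on this aromatic carbon can give results that lie within the usual scatter. Nothing measured here explains this result.

The exchange alters both the substituent and where it sits on the phenyl ring, so the contribution of each remains unresolved. Also open, from the compounds shown here alone, is whether a plain phenyl, a 4-aminophenyl or a phenyl bearing a carboxylic acid at this position would give a result that stays within the scatter of compound 2 and compound 3.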